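The compounds below may be only part of what the source reports. "The series", "measured", "known", "first", "only" and "open" are said of these compounds alone.

In a functional assay on brain (Rattus norvegicus, strain Wistar) for inhibition (on this read-out higher numbers stand for weaker inhibition and lower numbers for stronger inhibition), compound 1 (`Cc1[nH]c(=O)n(C)c1-c1ccccc1`) gives > 100000 nM, which is a limit of the assay and not a number. Compound 3 (`Cc1[nH]c(=O)n(C)c1-c1ccc(OC(C)C)cc1`) carries an isopropoxy group on the same shared core and gives 20400 nM. Among the compounds with values here, the one measured step here is an at least 4.9-fold lower number from compound 1 to compound 3 (0.69 log units; beyond the scatter), which lies beyond the scatter. Compound 2 (`CCCCc1ccc(-c2c(C)[nH]c(=O)n2Cc2ccccc2)cc1`), which has a butyl chain and also differs elsewhere, gives 12400 nM, so compound 3 stands within the scatter of it.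

Compound 4 (`CCCCCCc1ccc(-c2c(C)[nH]c(=O)n2C)cc1`) has hexyl in place of isopropoxy on an aromatic carbon. Within the data shown here, no measured step makes this exact exchange, so the evidence is indirect. The step of an at least 4.9-fold lower number from compound 1 to compound 3 (0.69 log units; beyond the scatter) shows that a group at this place can shift the number, and compound 2 at 12400 nM shows that a chain-bearing compound can reach a similar level. A small move towards a lower number in this assay is therefore expected, estimated as a 2.3-fold lower number from compound 3 to compound 4 (0.36 log units; beyond the scatter). The estimate for compound 4 is 9000 nM, with an expected range of 2500 nM to 30000 nM.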

Compound 4, half-maximal inhibitory concentration: 9000 nM
The estimate for compound 4 equals the measured number at the digits printed; the measured number falls inside the stated range.
By their numbers in this assay, from the lowest: compounds 4, 2 and 3 (each within the scatter of the next, the first and the last beyond it). At a limit, above all of these: compound 1.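

In this assay, the group on the aromatic carbon need not contain oxygen: hexyl, with no hydrogen-bond acceptor, in place of isopropoxy gives a 2.3-fold lower number from compound 3 to compound 4 (0.36 log units; beyond the scatter). Measured against the unsubstituted core, hexyl in place of hydrogen gives an at least 11-fold lower number from compound 1 to compound 4 (1.04 log units; beyond the scatter), a large step. Compound 1 gives a limit and not a number, so this step is only a bound: the limit of > 100000 nM in this assay, at which 1 of the 4 values shown sits.

Among the compounds shown, butyl appears only in compound 2, which also differs elsewhere, so the effect of chain length at this place cannot be separated from that other difference. As far as these compounds go, it also remains open whether a longer chain such as octyl would lower the number further, and how an amine or a carboxylic acid at this place would compare with hexyl.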